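A further methoxy on compound 3

This account rests on a few compounds, and the source may have more. Where it says the series, first, only, none or still open, it means among the compounds named here.

Values in a functional assay on A549 cells (Homo sapiens) for inhibition, read by MTT assay, with a stated time of 24 h; a higher number here means a weaker inhibitor of growth, a lower number a stronger inhibitor of growth:
- compound 1 `COc1ccccc1C(=O)n1c(-c2cn(C)c3ccccc23)nc2ccccc21`: 12300 nM
- compound 2 `COc1ccc(C(=O)n2c(-c3cn(C)c4ccccc34)nc3ccccc32)cc1`: 10400 nM
- compound 3 `COc1ccc(C(=O)n2c(-c3cn(C)c4ccccc34)nc3ccccc32)cc1OC`: 3100 nM

Compound 3 has the lowest number of the three. Compound 4 `COc1cc(C(=O)n2c(-c3cn(C)c4ccccc34)nc3ccccc32)cc(OC)c1OC` differs from it by methoxy in place of hydrogen on an aromatic carbon. Among the compounds with values here, the one measured step of the same kind is a 3.4-fold lower number from compound 2 to compound 3 (0.53 log units; beyond the scatter), a modest step beyond the scatter. Moving the methoxy gave a 1.2-fold lower number from compound 1 to compound 2 (0.07 log units; within the scatter), which says little about adding one. With a single precedent, a similar modest drop is expected, though a result within the scatter remains possible. In this assay the estimated change is a 1.9-fold lower number from compound 3 to compound 4 (0.29 log units; within the scatter). For compound 4 the estimate is 1600 nM, with an expected range from 600 nM to 3800 nM.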

Compound 4, concentration for 50% growth inhibition: 2600 nM
For compound 4 the middle estimate is 1.6-fold (0.21 log units) below the measured one, within the range that was stated.
By their numbers in this assay, from the lowest: compounds 4 and 3 (each within the scatter of the next); then compounds 2 and 1 (each within the scatter of the next).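

In this assay, methoxy in place of hydrogen, ortho to a methoxy group and meta to a large group, gives a 1.2-fold lower number from compound 3 to compound 4 (0.08 log units; within the scatter) and so does not repeat a 3.4-fold lower number from compound 2 to compound 3 (0.53 log units; beyond the scatter) as seen with the earlier added methoxy. The same change therefore does not carry the same step to this position, and compound 3 and compound 4 cannot be told apart here. No evidence at hand bears on the reason for this result.

Open, as far as these compounds go, is whether an amine or a hydroxy at this position would shift the number beyond the scatter. Also open, from the compounds shown here alone, is whether a longer chain such as ethoxy in place of this methoxy would do so.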